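Bromo for Fluoro on a Dimethoxy-Bearing Core

The source may report more compounds than this note shows. Statements on the series, on what has been measured and on what is new or still open speak of the compounds shown alone.

Compound 1, `O=S(=O)(/C=C/c1ccc(F)cc1)Cc1ccc(Nc2ncnc3ccccc23)cc1`, gives 2000 nM.
Compound 2, `O=S(=O)(/C=C/c1ccc(Br)cc1)Cc1ccc(Nc2ncnc3ccccc23)cc1`, gives 1000 nM.
Compound 3, `COc1cc2ncnc(Nc3ccc(CS(=O)(=O)/C=C/c4ccc(F)cc4)cc3)c2cc1OC`, is known only as a limit of the assay: > 100000 nM.

All three values come from a functional assay on SK-OV-3 cells (Homo sapiens); on this read-out lower numbers stand for stronger inhibition of growth and higher numbers for weaker inhibition of growth. Compound 1 and compound 2 share one core and differ in a single place: bromo in place of fluoro on an aromatic carbon. That change gave a 2.0-fold lower number from compound 1 to compound 2 (0.30 log units; within the scatter), a step within the usual scatter of such measurements.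

Compound 3 carries a different core, and the difference between the two cores is not broken down here. For compound 3 only a limit is reported, and one of the three values shown sits at that limit (the limit of > 100000 nM in this assay, at which 1 of the 3 values shown sits).

Compound 4, `COc1cc2ncnc(Nc3ccc(CS(=O)(=O)/C=C/c4ccc(Br)cc4)cc3)c2cc1OC`, has not yet been measured in this assay. It is to compound 3 what compound 2 is to compound 1: bromo in place of fluoro on an aromatic carbon. The place of the change reads the same in both pairs, so it is the same change on a different core.

Because the earlier step of a 2.0-fold lower number from compound 1 to compound 2 (0.30 log units; within the scatter) stayed within the scatter, compound 4 is expected to sit close to compound 3, and the estimated step is a number no higher from compound 3 to compound 4 (the limit leaves the size open). Compound 4 is therefore expected to give about 100000 nM in this assay, with a range from 40000 nM to 250000 nM, and most likely again only a limit.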

Compound 4, concentration for 50% growth inhibition: 50000 nM
Beside the measured number, compound 4's estimate is 2.0-fold (0.30 log units) above it; low and high end bracket the measured number.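

In this assay, putting bromo in place of fluoro on the aromatic ring of the second core gives an at least 2.0-fold lower number from compound 3 to compound 4 (0.30 log units; that floor lies within the scatter), and compound 4 has a measured value of 50000 nM. Compound 3 is known only as a limit of the assay, > 100000 nM, which means that only the smallest possible size of this step can be read, not its true size. The two steps fit the idea that the change behaves alike on both cores, but they do not prove it, and neither of them shows an effect of the change that clearly exceeds the ordinary spread of repeat measurements: the same change on two cores in this assay, a 2.0-fold lower number (0.30 log units; within the scatter) from compound 1 to compound 2 and an at least 2.0-fold lower number (0.30 log units; that floor lies within the scatter) from compound 3 to compound 4; the limit leaves it open whether they differ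

The compounds shown leave open how the same change would read on a third core, since two cores are a narrow base for any general rule about carrying it across a series. They also leave open what other groups would do at this position on the ring, for example chloro, a nitrile, a methoxy group, an amine or a carboxylic acid in place of the fluoro or bromo.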